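This account rests on a few compounds, and the source may have more. Where it says the series, first, only, none or still open, it means among the compounds named here.

Measured in a functional assay on HCT-15 cells (Homo sapiens) for antiproliferative activity, read by sulforhodamine B assay, with a stated time of 72 h; a lower number here means a stronger inhibitor, a higher number a weaker inhibitor:
- compound 1 `COc1cc(/C=C/COC(C)=O)ccc1OC(C)=O`: 3260 nM
- compound 2 `CCCC(=O)Oc1ccc(/C=C/COC(C)=O)cc1OC`: 17100 nM

Compound 1 holds the lower of these two numbers, so it is the stronger inhibitor of the pair. Among the compounds with values here, its only neighbour is compound 2, reached by a 5.2-fold higher number from compound 1 to compound 2 (0.72 log units; beyond the scatter), a modest step beyond the scatter. The next compound, compound 3 `CC[C@H](C)C(=O)OC/C=C/c1ccc(OC(C)=O)c(OC)c1`, changes compound 1 in this way: sec-butyl in place of methyl on a carbonyl carbon. In words, sec-butyl stands in place of methyl on a carbonyl carbon. Within the data shown here, the one measured step bears on this only loosely: it also adds carbon to an acetyl group, but to the other acetyl group of compound 1. With that single guide, a rise in the same direction is expected, probably smaller, though it could match. In this assay the expected change is a 2.5-fold higher number from compound 1 to compound 3 (0.39 log units; beyond the scatter). For compound 3 the estimated value is 8000 nM, with an expected range of 2500 nM to 25000 nM.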

Compound 3, half-maximal inhibitory concentration: 34100 nM
The estimate for compound 3 lay 4.3-fold (0.63 log units) below the measured number; measured number above the stated range.
By their numbers in this assay, from the lowest: compound 1; then compounds 2 and 3 (each within the scatter of the next).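

In this assay, placing sec-butyl in place of methyl on a carbonyl carbon gives a 10-fold higher number from compound 1 to compound 3 (1.02 log units; beyond the scatter) and marks this a large step beyond the scatter. This shows that the acetyl group changed here also tolerates enlargement poorly, whereas the earlier step spoke only to the other acetyl group of compound 1. Nothing given here accounts for this drop in activity.

The compounds shown do not separate the effect of the added carbons from that of the branched shape or the defined stereocentre, so an unbranched butyl chain, a smaller ethyl group and the mirror-image sec-butyl group remain open comparisons. From the compounds shown here alone, it also remains open how a free hydroxyl group in place of the acetoxy group at this position would compare with compound 1.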